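A Dimethylphenyl Swap Where Every Neighbour Sits at the Limit

A few compounds are considered here, and "the series" means these few. Any claim that something is new, unique, unknown or untested is made for them only; others in the source may bear on it.

In an ADME assay on L02 cells (Homo sapiens) for antiproliferative activity, read by MTT assay, with a stated time of 48 h (on this read-out lower numbers stand for stronger inhibition and higher numbers for weaker inhibition), compound 3 `N#CC1=C(N)Oc2c(c3nc4ccccc4nc3c3ccccc23)C12C(=O)N(Cc1cnnn1-c1ccc([N+](=O)[O-])cc1)c1ccccc12` gives only a limit of the assay, > 50000 nM. Compound 1 `N#CC1=C(N)Oc2c(c3nc4ccccc4nc3c3ccccc23)C12C(=O)N(Cc1cnnn1-c1ccc(Cl)cc1)c1ccccc12` likewise gives a limit rather than a number, > 50000 nM. Compound 2 `COc1ccccc1-n1nncc1CN1C(=O)C2(C(C#N)=C(N)Oc3c2c2nc4ccccc4nc2c2ccccc32)c2ccccc21` also gives a limit, > 50000 nM. All three therefore rest at the limit of > 50000 nM in this assay, at which 3 of the 3 values shown sit, and none of the steps between them can be read: a step that the two limits leave unreadable from compound 1 to compound 2, a step that the two limits leave unreadable from compound 1 to compound 3 and a step that the two limits leave unreadable from compound 2 to compound 3 are each hidden by that limit.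

Compound 4 `Cc1ccc(-n2nncc2CN2C(=O)C3(C(C#N)=C(N)Oc4c3c3nc5ccccc5nc3c3ccccc43)c3ccccc32)cc1C` has not been measured. It differs from compound 3 in one place: 3,4-dimethylphenyl in place of 4-nitrophenyl on an aromatic nitrogen. The three measured steps bear on this change only loosely, since each of them also swaps the aryl group on the same aromatic nitrogen, and each of them was unreadable. Among the measured compounds shown here, no measured step therefore points to a direction or a size for the present change. The expectation for compound 4 in this assay is accordingly a step that the limit leaves unreadable from compound 3 to compound 4 that cannot be told apart from no change at all. The estimate for compound 4 is 80000 nM, within a range from 30000 nM to 300000 nM, and most probably reported once more as a limit rather than a number.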

Compound 4, half-maximal inhibitory concentration: > 50000 nM
Compound 4 was reported as a limit; the forecaster's own chance of this, stated with the estimate: 85%; the middle value is on the limit's open side.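

Compound 4 gives only a limit of the assay (> 50000 nM). Its steps from compound 1, compound 2 and compound 3 therefore cannot be read, and all four compounds sit together: (the limit of > 50000 nM in this assay, at which 4 of the 4 values shown sit). The compounds shown leave open what their actual values are, and whether changing the aryl group on the aromatic nitrogen makes any difference in this assay at all.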